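Aryl amide exchange tested on two core variants

The source may hold more compounds than are shown below. What is called first, only, known or untested is meant among the compounds shown, and "the series" means these compounds.

In a functional assay on HL-60 cells (Homo sapiens) for antiproliferative activity, with a stated time of 24 h (on this read-out higher numbers stand for weaker inhibition and lower numbers for stronger inhibition), compound 1 `NC(=O)c1c(NC(=O)c2ccccc2F)sc2c1CCN(C(=O)Nc1ccccc1Cl)C2` gives 32700 nM. Compound 2 `NC(=O)c1c(NC(=O)c2ccc(C(F)(F)F)cc2)sc2c1CCN(C(=O)Nc1ccccc1Cl)C2` carries 4-(trifluoromethyl)phenyl in place of 2-fluorophenyl on a carbonyl carbon. In this assay compound 2 reaches only a limit, > 50000 nM. The step is an at least 1.5-fold higher number from compound 1 to compound 2 (0.18 log units; that floor lies within the scatter), and the value sits at the limit of > 50000 nM in this assay, at which 1 of the 3 values shown sits. Compound 3 `NC(=O)c1c(NC(=O)c2ccccc2F)sc2c1CCN(C(=S)Nc1cc(C(F)(F)F)cc(C(F)(F)F)c1)C2` gives 17900 nM in this assay; the difference between the core of compound 3 and the core of compound 1 is not broken down here. Compound 4 `NC(=O)c1c(NC(=O)c2ccc(C(F)(F)F)cc2)sc2c1CCN(C(=S)Nc1cc(C(F)(F)F)cc(C(F)(F)F)c1)C2` carries 4-(trifluoromethyl)phenyl in place of 2-fluorophenyl on a carbonyl carbon, the same change already seen once in the series. Since the earlier step was an at least 1.5-fold higher number from compound 1 to compound 2 (0.18 log units; that floor lies within the scatter) and ended at a limit, a weakening of at least that size is expected, and a value reported only as a limit is possible. For compound 4 the expected step is a 2.5-fold higher number from compound 3 to compound 4 (0.40 log units; beyond the scatter). For compound 4 the expected value is 45000 nM, with a range from 22000 nM to 120000 nM.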

Compound 4, half-maximal inhibitory concentration: 16300 nM
The estimate for compound 4 lay 2.8-fold (0.44 log units) above the measured number; measured number outside the range, below it.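

Moved to the other core, the exchange of 2-fluorophenyl for 4-(trifluoromethyl)phenyl on the carbonyl carbon gives a 1.1-fold lower number from compound 3 to compound 4 (0.04 log units; within the scatter) in this assay, so no change is seen there. Compound 2 stands only at a limit of the assay, > 50000 nM, so the step on the core of compound 1 has a floor but no size. The two steps show neither that the exchange carries over unchanged nor that its outcome depends on the core: the same change on two cores in this assay, an at least 1.5-fold higher number (0.18 log units; that floor lies within the scatter) from compound 1 to compound 2 and a 1.1-fold lower number (0.04 log units; within the scatter) from compound 3 to compound 4; the limit leaves it open whether they differ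

Open, as far as these compounds go, is how much of the difference between compound 1 and compound 3 belongs to each place that changes. Also open, from the compounds shown here alone, is how a phenyl carrying an amine or a carboxylic acid would read on each core in place of these two groups on the carbonyl carbon.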